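The source may hold more compounds than are shown below. What is called first, only, known or untested is meant among the compounds shown, and "the series" means these compounds.

Measured so far in a functional assay on A549 cells (Homo sapiens) for antiproliferative activity, read by MTT assay, with a stated time of 48 h; a lower number here means a stronger inhibitor, a higher number a weaker inhibitor:
compound 1 `CC(C)=CCC[C@]1(C)/C=C/[C@@H](OC(=O)C=C(C)C)[C@](C)(O)/C=C/C(=O)/C(CCl)=C\C1`: 150 nM
compound 2 `CC(C)=CCC[C@]1(C)/C=C/[C@@H](OC(=O)C=C(C)C)[C@](C)(O)/C=C/C(O)/C(C=O)=C\C1`: 570 nM

Compound 1 gives the lowest of the two numbers; compound 2 is the nearest, with a higher number, and that gap lies beyond the scatter. Compound 3 `CO/N=C/C1=C/C[C@](C)(CCC=C(C)C)/C=C/[C@@H](OC(=O)C=C(C)C)[C@](C)(O)/C=C/C1=O` is not yet measured. It differs from compound 1 in one place: a group of 4 heavy atoms (2 carbon, 1 nitrogen, 1 oxygen; no ring) in place of a group of 2 heavy atoms (1 carbon, 1 chlorine; no ring), on a double-bonded ring carbon. Among the measured compounds shown here, no step between measured compounds touches this place, so the size of the move cannot be read from the data. The expectation is a moderate rise in the number, beyond the scatter, as a 5.3-fold higher number from compound 1 to compound 3 (0.73 log units; beyond the scatter). For compound 3 the estimate is 800 nM, within 250 nM to 3000 nM.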

Compound 3, half-maximal inhibitory concentration: 3470 nM
For compound 3 the middle estimate is 4.3-fold (0.64 log units) below the measured one; the whole stated range lies below it.
By their numbers in this assay, from the lowest: compound 1; then compound 2; then compound 3.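

At this double-bonded ring carbon the group matters strongly: in this assay, exchanging chloromethyl for the entering group of carbon, nitrogen and oxygen gives a 23-fold higher number from compound 1 to compound 3 (1.36 log units; beyond the scatter) with the rest of the core unchanged. Among the compounds shown here, this is the only single-place step at this position, so it sets a first size for what a change there can do. Nothing available explains the size of this step.

One step cannot separate the loss of chlorine from the arrival of the entering group. On these data alone, whether a methyl, a hydroxymethyl or an aminomethyl group at this carbon would stay near compound 1 or move toward compound 3 remains open.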